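This account rests on a few compounds, and the source may have more. Where it says the series, first, only, none or still open, it means among the compounds named here.

Working notes on the series. In a functional assay on CHO cells for agonist activity at Free fatty acid receptor 1 (Homo sapiens), read by FLIPR and calcium flux, tested at 1 uM (on this read-out lower numbers stand for an effect already at smaller amounts and higher numbers for an effect only at larger amounts of compound), compound 1 `Cc1ccc(OCc2nnc(C(=O)Nc3ccc(CCC(=O)O)cc3)s2)c(C)c1` gives 2540 nM, and compound 2 `CCc1ccc(OCc2nnc(C(=O)Nc3ccc(CCC(=O)O)cc3)s2)cc1` gives 1170 nM. Going by the values given here, compound 2 holds the lower of the two numbers; the only measured step is a 2.2-fold lower number from compound 1 to compound 2 (0.34 log units; beyond the scatter). Compound 3 `COc1ccc(OCc2nnc(C(=O)Nc3ccc(CCC(=O)O)cc3)s2)cc1` differs from compound 2 by methoxy in place of ethyl on an aromatic carbon. Among the compounds with values here, no measured step touches this exchange; the single step from compound 1 to compound 2 concerns other substituents, so it gives no direction here. For compound 3 the expected step is a 1.3-fold higher number from compound 2 to compound 3 (0.11 log units; within the scatter), that is no change beyond the scatter. The estimate for compound 3 is therefore 1500 nM, with a range from 500 nM to 4500 nM.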

Compound 3, half-maximal effective concentration: 2430 nM
Compound 3: middle estimate off by 1.6-fold (0.21 log units), on the low side, within the range that was stated.
By their numbers in this assay, from the lowest: compound 2; then compounds 3 and 1 (each within the scatter of the next).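

Methoxy in place of ethyl on this aromatic carbon, para to a large group, moves the number in this assay (a 2.1-fold higher number from compound 2 to compound 3 (0.32 log units; beyond the scatter)), so this position does respond to the exchange. The 4-methoxyphenyl and 2,4-dimethylphenyl compounds are not separated (a 1.0-fold lower number from compound 1 to compound 3 (0.02 log units; within the scatter)), and only the 4-ethylphenyl of compound 2 stands apart from both. Nothing available explains the gap between ethyl and methoxy. Open, on these data alone, is how a longer chain such as propyl, or an amine or a chlorine, would read at this position.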